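Adding One Fluoro to a Long-Lived Compound

A few compounds are considered here, and "the series" means these few. Any claim that something is new, unique, unknown or untested is made for them only; others in the source may bear on it.

- Compound 1 `COc1n[nH]c2ncc(NC(=O)c3c(F)ccc(/N=N\c4ccccc4)c3F)cc12`: > 10 h
- Compound 2 `COc1ccc(/N=N\c2cccc(C(=O)Nc3cnc4[nH]nc(OC)c4c3)c2)cc1`: > 10 h

In an unclassified assay for pharmacokinetics, read by NMR, tested at 2 mg/mL (on this read-out lower numbers stand for a shorter-lived compound and higher numbers for a longer-lived compound), compound 1 stands at > 10 h, which is a limit and not a number. Compound 2 gives > 10 h, also a limit. Among the compounds with values here, the only evidence is therefore (the limit of > 10 h in this assay, at which 2 of the 2 values shown sit). Compound 3 `COc1n[nH]c2ncc(NC(=O)c3c(F)ccc(/N=N\c4ccccc4F)c3F)cc12` has fluoro in place of hydrogen on an aromatic carbon, ortho to a large group (fluoro in place of hydrogen on an aromatic carbon). Within the data shown here, no measured step shows what such a change does, so none beyond the scatter is expected in this assay. The expected change is a step that the limit leaves unreadable from compound 1 to compound 3. For compound 3 the estimate is 25 h, with an expected range of 10 h to 80 h.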

Compound 3, half-life: > 20 h
Compound 3: a limit, no number; the forecaster's own chance of this, stated with the estimate: 70%; the middle value lies beyond the limit too.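

No step can be read from compound 1 to compound 3: both results are limits, not numbers. The compounds shown leave open the actual half-life of each and whether fluoro in place of hydrogen changes it at all.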